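Solubility notes: piperidinyl replaces dimethylpiperazinyl on the aminopyridine

The source may report more compounds than this note shows. Statements on the series, on what has been measured and on what is new or still open speak of the compounds shown alone.

In a physicochemical assay for solubility, read by HPLC, using the shake flask method, in phosphate buffer, measured as kinetic solubility, with a stated time of 20 h, at pH 6.5 (on this read-out lower numbers stand for lower solubility and higher numbers for higher solubility), compound 3 `C[C@@H]1CN(c2ccc(Nc3nc4cnc(Nc5ccc(F)c(F)c5)cc4[nH]3)nc2)C[C@H](C)N1` gives 175000 nM, the highest number in the set. Compound 2 `Fc1ccc(Nc2cc3[nH]c(Nc4ccc(N5CCN(CC6CC6)CC5)cn4)nc3cn2)cc1F` gives 10000 nM in this assay, and the step of an 18-fold higher number from compound 2 to compound 3 (1.24 log units; beyond the scatter) is well beyond the scatter. Compound 1 `Fc1ccc(Nc2cc3[nH]c(Nc4ccc(N5CCNCC5)cn4)nc3cn2)cc1F` sits at a limit of this assay, < 5000 nM, so its value is a bound rather than a number (the limit of < 5000 nM in this assay, at which 1 of the 3 values shown sits); the step of an at least 35-fold higher number from compound 1 to compound 3 (1.54 log units; beyond the scatter) is also large.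

Compound 4 `Fc1ccc(Nc2cc3[nH]c(Nc4ccc(C5CCNCC5)cn4)nc3cn2)cc1F` differs from compound 3 by piperidin-4-yl in place of 3,5-dimethylpiperazin-1-yl on an aromatic carbon. Both measured steps that reach compound 3 run toward it and uphill; the change to compound 4 undoes the 3,5-dimethylpiperazin-1-yl and leaves a ring with one hetero atom, nearer in shape to the piperazin-1-yl of compound 1 than to anything else measured. Within the data shown here, a drop in this assay beyond the scatter is therefore expected, of about a 12-fold lower number from compound 3 to compound 4 (1.07 log units; beyond the scatter), though no measured pair shows this exact exchange, so the size is uncertain. Compound 4 is estimated at 15000 nM in this assay, within 3000 nM to 60000 nM.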

Compound 4, solubility: 190000 nM
Compound 4: the middle estimate sits 13-fold (1.10 log units) below what was measured; the whole stated range lies below it.
By their numbers in this assay, from the lowest: compound 2; then compounds 3 and 4 (each within the scatter of the next). At a limit, below all of these: compound 1.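

In this assay, piperidin-4-yl in place of 3,5-dimethylpiperazin-1-yl on the aromatic carbon gives a 1.1-fold higher number from compound 3 to compound 4 (0.04 log units; within the scatter), so a high number at this position does not depend on a second ring nitrogen or on the two defined stereocentres. The step of a 19-fold higher number from compound 2 to compound 4 (1.28 log units; beyond the scatter) shows that this smaller ring, like 3,5-dimethylpiperazin-1-yl, stands well clear of the 4-(cyclopropylmethyl)piperazin-1-yl group. The step of an at least 38-fold higher number from compound 1 to compound 4 (1.57 log units; beyond the scatter) is only a floor, as its starting value is a limit and not a number: the limit of < 5000 nM in this assay, at which 1 of the 4 values shown sits.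

As far as these compounds go, it remains open whether a high number holds with morpholin-4-yl or with cyclohexyl, a ring with no hetero atom, at this position. The compounds shown also give no reason for the wide gap between the unsubstituted piperazin-1-yl and piperidin-4-yl.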